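Methoxy in place of methyl: one change made twice

The source may hold more compounds than are shown below. What is called first, only, known or untested is meant among the compounds shown, and "the series" means these compounds.

Measured so far in a functional assay on A549 cells (Homo sapiens) for inhibition, read by MTT assay, with a stated time of 48 h; on this read-out higher numbers stand for weaker inhibition and lower numbers for stronger inhibition:
compound 1 `Cc1ccc(-n2cc(NC(=O)c3cccc(NS(=O)(=O)c4ccccc4)c3)cn2)cc1` gives 18900 nM
compound 2 `COc1ccc(-n2cc(NC(=O)c3cccc(NS(=O)(=O)c4ccccc4)c3)cn2)cc1` gives 76800 nM
compound 3 `Cc1ccc(-n2cc(NC(=O)c3ccc(NS(=O)(=O)c4ccc(Cl)cc4)cc3)cn2)cc1` gives 22000 nM

Compound 1 and compound 2 share a core and differ only in methoxy in place of methyl on an aromatic carbon. The step of a 4.1-fold higher number from compound 1 to compound 2 (0.61 log units; beyond the scatter) is the one measured effect of that change in this set.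

Compound 3 carries a different core; the difference between the core of compound 3 and the core of compound 1 is not broken down here. In this assay compound 3 sits close to compound 1, the two values lying within the usual scatter of each other, while compound 2 gives a number clearly higher than compound 3.

Compound 4 `COc1ccc(-n2cc(NC(=O)c3ccc(NS(=O)(=O)c4ccc(Cl)cc4)cc3)cn2)cc1` is not yet measured. It stands to compound 3 as compound 2 stands to compound 1: the change is methoxy in place of methyl on an aromatic carbon, and since the place is described in the same words for both pairs, this is the same change rather than merely the same kind. Among the compounds with values here, the only guide to its size is the single earlier step, because a 4.1-fold higher number from compound 1 to compound 2 (0.61 log units; beyond the scatter) is the one precedent, on a different core. The expectation for compound 4 is therefore a step of about the same size, a 3.2-fold higher number from compound 3 to compound 4 (0.50 log units; beyond the scatter), with a wide band to allow for the change of core. Compound 4 is expected to give 70000 nM in this assay, within a range from 30000 nM to 160000 nM.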

Compound 4, half-maximal inhibitory concentration: 61000 nM
Compound 4: middle estimate off by 1.1-fold (0.06 log units), on the high side; the measured number falls inside the stated range.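

In this assay, going from 4-methylphenyl to 4-methoxyphenyl again moves the read-out towards weaker inhibition, with a 2.8-fold higher number from compound 3 to compound 4 (0.44 log units; beyond the scatter), so on both cores shown the change runs in the same direction and is beyond the scatter. Within the data shown here, the two steps can be read as one effect of similar size, and the difference between them gives no sign that the core of compound 3 alters the outcome of this change compared with the core of compound 1: the same change on two cores in this assay, a 4.1-fold higher number (0.61 log units; beyond the scatter) from compound 1 to compound 2 and a 2.8-fold higher number (0.44 log units; beyond the scatter) from compound 3 to compound 4, 1.5-fold (0.17 log units) apart, within the scatter of two such steps This agreement rests on only two pairs in a single cell assay, so it supports carrying the change between these two cores but is no rule for other cores of the series, and it says nothing about why methoxy gives the higher number or which of the differences between the two cores, if any, might matter.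

Going by these compounds, what a fluorine, a hydroxyl, an amine or a carboxylic acid would do on the same aromatic carbon remains open, and so does the effect of a longer chain such as ethoxy in place of methoxy. Also open, on these data alone, is whether any replacement of methyl at that place gives a lower number rather than a higher one.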